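This account rests on a few compounds, and the source may have more. Where it says the series, first, only, none or still open, it means among the compounds named here.

Measured in a functional assay on MDA-MB-231 cells (Homo sapiens) for inhibition, read by sulforhodamine B assay, with a stated time of 48 h, tested at 10 uM; a lower number here means less inhibition of growth, a higher number more inhibition of growth at the concentration tested:
- compound 1 `CC(=O)c1cccc(Nc2ccnc(SCC(=O)c3ccc(-c4ccccc4)cc3)n2)c1`: 41%
- compound 2 `CC(=O)c1ccc(Nc2ccnc(SCC(=O)c3ccc(-c4ccccc4)cc3)n2)cc1`: 22%

Not yet measured:
- compound 3 `CC(=O)c1cccc(Nc2ccnc(SCC(=O)c3ccc(C(F)(F)F)cc3)n2)c1`

Of the two measured compounds, compound 1 stands highest at 41%. Compound 3 keeps the core of compound 1 and changes one group, with trifluoromethyl in place of phenyl on an aromatic carbon. Going by the values given here, only one measured step is available, a number 19 percentage points lower from compound 1 to compound 2 (beyond the scatter). It swaps 3-acetylphenyl for 4-acetylphenyl, a different group from the one changing now, so it bears on this change only indirectly. It shows that one small edit can move this read-out by a modest amount. Among the compounds with values here, no measured step covers the phenyl group itself, so the direction remains uncertain. A modest fall in this assay is the cautious expectation. The estimated step is a number 11 percentage points lower from compound 1 to compound 3 (beyond the scatter). For compound 3 the expected value is 30%, with an estimated range of 10% to 52%.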

Compound 3, percent growth inhibition at one concentration: 22%
Beside the measured number, compound 3's estimate is 8 percentage points above it; the measured number falls inside the stated range.
By their numbers in this assay, from the lowest: compounds 2 and 3 (each within the scatter of the next); then compound 1.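

Going by these compounds alone, the earlier pair varied only the acetylphenyl group, so this is the first reading at the aromatic carbon that carries the phenyl. In this assay the change from phenyl, a six-membered aromatic ring of carbon only, to trifluoromethyl, which has no ring, gives a number 19 percentage points lower from compound 1 to compound 3 (beyond the scatter) and so shows that this position also affects growth inhibition. Nothing available explains the loss, so the result records what the change did and not why it did so.

Going by these compounds, whether a chlorine atom, a methoxy group or a pyridine ring at this position would keep the growth inhibition of compound 1 stays open. Also open, on these data alone, is whether the same exchange would change the number similarly on a molecule carrying 4-acetylphenyl in place of 3-acetylphenyl.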